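Swapping a Chloropyridinone for Methyl: Expected Permeability

The compounds below may be only part of what the source reports. "The series", "measured", "known", "first", "only" and "open" are said of these compounds alone.

Three measured compounds share one core and differ only in the group attached to the sulfonyl-bearing ring. Compound 1 `CCCCc1nc(=O)c(S(=O)(=O)c2ccc(-c3ccc(F)cc3)cc2)c(O)n1-c1c(OC)cccc1OC` gives 418 nm/s in an ADME assay for permeability, using PAMPA, at pH 5.5; on this read-out higher numbers stand for higher permeability and lower numbers for lower permeability. Compound 2 `CCCCc1nc(=O)c(S(=O)(=O)c2ccc(-c3cccnc3)cc2)c(O)n1-c1c(OC)cccc1OC` gives 202 nm/s in this assay. Compound 3 `CCCCc1nc(=O)c(S(=O)(=O)c2ccc(-n3cc(Cl)ccc3=O)cc2)c(O)n1-c1c(OC)cccc1OC` gives 83 nm/s in this assay, the lowest of the three numbers. Between them the steps were a 2.1-fold lower number from compound 1 to compound 2 (0.32 log units; beyond the scatter), a 5.0-fold lower number from compound 1 to compound 3 (0.70 log units; beyond the scatter) and a 2.4-fold lower number from compound 2 to compound 3 (0.39 log units; beyond the scatter).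

Compound 4 `CCCCc1nc(=O)c(S(=O)(=O)c2ccc(C)cc2)c(O)n1-c1c(OC)cccc1OC` differs from compound 3 by one carbon atom in place of a group of 8 heavy atoms (5 carbon, 1 nitrogen, 1 oxygen, 1 chlorine; one six-membered aromatic ring with 1 hetero atom), on an aromatic carbon. Among the compounds with values here, the steps that bear on this change are those leading into compound 3, above all a 5.0-fold lower number from compound 1 to compound 3 (0.70 log units; beyond the scatter), where the ring now removed was introduced in place of a single ring of carbon only. Taking the ring away altogether, leaving only a methyl, is expected to move the number back in the opposite direction, and the expected step in this assay is a 5.1-fold higher number from compound 3 to compound 4 (0.70 log units; beyond the scatter), a rise beyond the scatter. For compound 4 the estimate in this assay is 420 nm/s, with a range from 200 nm/s to 850 nm/s.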

Compound 4, apparent permeability: 243 nm/s
The estimate for compound 4 lay 1.7-fold (0.24 log units) above the measured number; the measured number falls inside the stated range.
By their numbers in this assay, from the lowest: compound 3; then compounds 2, 4 and 1 (each within the scatter of the next, the first and the last beyond it).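

Cutting the ring group of compound 3 down to a methyl gives a 2.9-fold higher number from compound 3 to compound 4 (0.47 log units; beyond the scatter) in this assay and shows that a much smaller group at this position can carry a number well clear of that of compound 3. The methyl cannot be told apart from either of the other two ring groups, with a 1.2-fold higher number from compound 2 to compound 4 (0.08 log units; within the scatter) and a 1.7-fold lower number from compound 1 to compound 4 (0.24 log units; within the scatter) even though a 2.1-fold lower number from compound 1 to compound 2 (0.32 log units; beyond the scatter) separates those two from each other. Among these four compounds, then, having a ring on this aromatic carbon does not by itself go with the lowest number, since only compound 3 stands apart from all the others, and no measurement offered here explains the differences.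

The compounds leave open whether the low number of compound 3 goes with its chlorine or with its ring carbonyl. They also leave open how this position would respond to an amine, a carboxylic acid or a longer chain such as butyl.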